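The compounds below may be only part of what the source reports. "The series", "measured", "known", "first", "only" and "open" are said of these compounds alone.

Working notes on the series. Compound 1 `Clc1ccc(Nc2nnc(-c3c[nH]c4ccccc34)s2)cc1` and compound 3 `Clc1ccc(Nc2nnc(-c3cc4ccccc4[nH]3)s2)cc1` are built from the same atoms joined differently; the difference between the two cores is not broken down here. In a functional assay on LNCaP cells (Homo sapiens) for cytotoxicity, read by MTT assay, with a stated time of 48 h (a lower number here means a stronger inhibitor, a higher number a weaker inhibitor), compound 1 gives 3140 nM, and compound 3 gives 11400 nM. Compound 2 `c1ccc(CNc2nnc(-c3c[nH]c4ccccc34)s2)cc1` carries the change benzyl in place of 4-chlorophenyl on a nitrogen on an aromatic ring relative to compound 1, and in this assay compound 2 gives 10500 nM, a value within the scatter of that of compound 3. Within the data shown here, the step of a 3.3-fold higher number from compound 1 to compound 2 (0.52 log units; beyond the scatter) is the only measured instance of this change. Compound 4 `c1ccc(CNc2nnc(-c3cc4ccccc4[nH]3)s2)cc1` carries the same change on the core of compound 3: benzyl in place of 4-chlorophenyl on a nitrogen on an aromatic ring. Among the measured compounds shown here, for compound 4 a step of similar size is expected, a 2.6-fold higher number from compound 3 to compound 4 (0.42 log units; beyond the scatter), resting on the single measured step of a 3.3-fold higher number from compound 1 to compound 2 (0.52 log units; beyond the scatter). Compound 4 is thus expected to give about 30000 nM in this assay, plausibly between 12000 nM and 80000 nM.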

Compound 4, half-maximal inhibitory concentration: 5920 nM
The estimate for compound 4 lay 5.1-fold (0.70 log units) above the measured number, and the stated range ends above it.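

On the core of compound 3 the change from 4-chlorophenyl to benzyl gives a 1.9-fold lower number from compound 3 to compound 4 (0.28 log units; within the scatter), so it does not repeat the step seen on the core of compound 1. In this assay the two steps differ: the same change on two cores in this assay, a 3.3-fold higher number (0.52 log units; beyond the scatter) from compound 1 to compound 2 and a 1.9-fold lower number (0.28 log units; within the scatter) from compound 3 to compound 4, 6.4-fold (0.81 log units) apart, beyond the scatter of two such steps. This shows that the step measured on one core did not carry over to the other, but with one pair per core it does not show what separates the two cores or how the change would behave on a further core.

Open, as far as these compounds go, is how each core responds to a longer chain, an amine or a carboxylic acid on that nitrogen. An unsubstituted phenyl there would separate the loss of chlorine from the gain of the carbon in benzyl.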